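This account rests on a few compounds, and the source may have more. Where it says the series, first, only, none or still open, it means among the compounds named here.

The series shares the core of compound 1 `CCc1cc(C(C)=O)c(O)cc1OCCCC(C)(C)C(=O)O` and varies the far end of the ether chain. In an assay on isolated protein for inhibition of leukotriene B4 receptor 1 (Homo sapiens), tested at 10 uM (on this read-out higher numbers stand for more inhibition at the one concentration tested (going by the name of the read-out) and lower numbers for less inhibition), compound 1 gives 89%. Compound 2 `CCc1cc(C(C)=O)c(O)cc1OCCCCCCSC` gives 71% in this assay. Going by the values given here, the only measured step, a number 18 percentage points lower from compound 1 to compound 2 (beyond the scatter), put 3-(methylsulfanyl)propyl in place of 1-carboxy-1-methylethyl on a saturated chain carbon, three bonds along the chain from an oxygen on an aromatic ring. Among the compounds with values here, compound 2 therefore stands lowest of the two numbers so far, with compound 1 as its nearest and higher neighbour. Compound 3 `CCc1cc(C(C)=O)c(O)cc1OCCCCCCC(=O)N(C)C` carries dimethylcarbamoyl in place of methylsulfanyl on a saturated chain carbon, six bonds along the chain from an oxygen on an aromatic ring. Within the data shown here, no measured step covers this exchange; only a number 18 percentage points lower from compound 1 to compound 2 (beyond the scatter) touches the chain end, and it shows that the end group can shift the reading by a modest amount. For compound 3 a reading from unchanged to slightly higher is expected, as a number 4 percentage points higher from compound 2 to compound 3 (within the scatter). Compound 3 is estimated at 75%, within 55% to 92%.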

Compound 3, a percentage reported as inhibition, at one concentration (the size of the read-out at that concentration, not a potency): 100%
Compound 3: the middle estimate sits 25 percentage points below what was measured; measured number above the stated range.
By their numbers in this assay, from the lowest: compound 2; then compound 1; then compound 3.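

In this assay, dimethylcarbamoyl in place of methylsulfanyl on a saturated chain carbon, six bonds along the chain from an oxygen on an aromatic ring, gives a number 29 percentage points higher from compound 2 to compound 3 (beyond the scatter), so changes at the chain end can raise the reading as well as lower it. With 3-(dimethylcarbamoyl)propyl in place of 1-carboxy-1-methylethyl, the result is a number 11 percentage points higher from compound 1 to compound 3 (beyond the scatter), so among these three compounds the top reading does not depend on the carboxylic acid end. The data shown offer no explanation for either step.

Left open is whether a primary amide or an amine at the chain end would hold the reading, and whether a shorter or longer chain would keep it. These single-concentration readings also give no potency for any of the three compounds.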